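The source may report more compounds than this note shows. Statements on the series, on what has been measured and on what is new or still open speak of the compounds shown alone.

Among the compounds with values here, in a physicochemical assay for solubility, read by HPLC, with a stated time of 24 h (a higher number here means a more soluble compound, a lower number a less soluble compound), compound 2 `O=CNC[C@H]1CN(c2ccc(-n3cc(-c4ccccn4)cn3)c(F)c2)C(=O)O1` gives 217000 nM, the higher of the two numbers measured so far. Compound 1 `COC(=O)CC1CCN(C[C@H]2CN(c3ccc(-n4cc(-c5ccccn5)cn4)c(F)c3)C(=O)O2)CC1` gives 92100 nM, and the step of a 2.4-fold higher number from compound 1 to compound 2 (0.37 log units; beyond the scatter) lies beyond the scatter. Compound 3 `O=C(NC[C@H]1CN(c2ccc(-n3cc(-c4ccccn4)cn3)c(F)c2)C(=O)O1)C(F)F` differs from compound 2 by difluoromethyl in place of hydrogen on a carbonyl carbon. Within the data shown here, no measured step exchanges hydrogen for difluoromethyl on a carbonyl carbon, so the single measured step is only a loose guide, and a shift of at most modest size, most likely within the scatter, is expected. Compound 3 is therefore estimated at 150000 nM, between 70000 nM and 320000 nM. The expected step is a 1.4-fold lower number from compound 2 to compound 3 (0.16 log units; within the scatter).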

Compound 3, solubility: 29900 nM
Estimate against measurement, compound 3: 5.0-fold (0.70 log units) above; the whole stated range lies above it.
By their numbers in this assay, from the lowest: compound 3; then compound 1; then compound 2.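

In this assay, the carbonyl carbon of the formylamino group proves to be a sensitive place: difluoromethyl in place of hydrogen there brings a clear fall (a 7.3-fold lower number from compound 2 to compound 3 (0.86 log units; beyond the scatter)). Compound 3 also ends up under compound 1 (a 3.1-fold lower number from compound 1 to compound 3 (0.49 log units; beyond the scatter)), so the piperidine side chain of compound 1 no longer marks the low end. Nothing measured here accounts for this fall.

As far as these compounds go, it remains open whether the fall follows the fluorine atoms or simply the added carbon, which a plain methyl on this carbonyl carbon would separate. From the compounds shown here alone, how a trifluoromethyl or an amino group there would read also stays open.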